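The compounds below may be only part of what the source reports. "The series", "measured", "known", "first", "only" and "open" are said of these compounds alone.

In an ADME assay on Huh7.5.1 cells (Homo sapiens) for cytotoxicity, read by WST assay, with a stated time of 48 h (a lower number here means that less compound is tolerated, a higher number that more compound is tolerated), the measured compounds read as follows:

Compound 1 (`Cc1c(-c2ccc(Cc3ccc(OCC(F)(F)F)cc3)cc2)[nH]c2cccc(F)c2c1=O`) | > 5000 nM | a limit
Compound 2 (`Cc1c(-c2ccc(Cc3ccc([S+]([O-])C(F)(F)F)cc3)cc2)[nH]c2cccc(F)c2c1=O`) | > 5000 nM | a limit
Compound 3 (`Cc1c(-c2ccc(Cc3ccc(OC(F)F)cc3)cc2)[nH]c2cccc(F)c2c1=O`) | > 5000 nM | a limit

Each of these entries is a limit of the assay and not a number. Compound 3 therefore has no exact position on the scale, and the whole set rests on the limit of > 5000 nM in this assay, at which 3 of the 3 values shown sit, and on nothing sharper.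

The next compound is compound 4 (`Cc1c(-c2ccc(Cc3ccc(Cl)cc3)cc2)[nH]c2cccc(F)c2c1=O`). Its difference from compound 3 is chloro in place of difluoromethoxy on an aromatic carbon (chloro in place of difluoromethoxy on an aromatic carbon, para to a large group). The group at that place has been swapped before. The measured steps that bear on this are a step that the two limits leave unreadable from compound 1 to compound 3 and a step that the two limits leave unreadable from compound 2 to compound 3 and also a step that the two limits leave unreadable from compound 1 to compound 2 in the same set. None of them has a size that can be read, so they give only a loose guide.

Because the limit of > 5000 nM in this assay, at which 3 of the 3 values shown sit, covers compound 1, compound 2 and compound 3 with three different groups at that place, no step beyond the usual scatter is expected in this assay and another limit is the likeliest report. The estimated change is a step that the limit leaves unreadable from compound 3 to compound 4 and no more. Compound 4 is estimated at 7000 nM (expected range 3000 nM to 20000 nM).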

Compound 4, half-maximal cytotoxic concentration: > 10000 nM
Compound 4 was reported as a limit; the forecaster's own chance of this, stated with the estimate: 75%; middle value at least 1.4-fold (0.15 log units) away from the limit.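

In this assay compound 4 gives > 10000 nM, which is a limit of the assay and not a number. The steps to compound 4 from compound 1, compound 2 and compound 3 cannot be read. The compounds shown leave open at what concentration any of these four compounds would reach its half-maximal cytotoxic effect in this assay.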